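The source may hold more compounds than are shown below. What is called first, only, known or untested is meant among the compounds shown, and "the series" means these compounds.

The measured compounds and their values in a functional assay on KYSE-510 cells (Homo sapiens) for antiproliferative activity, read by crystal violet staining, with a stated time of 96 h; on this read-out lower numbers stand for stronger inhibition of growth and higher numbers for weaker inhibition of growth:

compound 1, `O=S(=O)(NC1=NCCN1C(=S)SN1CCn2c1nsc2=S)c1ccccc1`: >= 20000 nM
compound 2, `COc1cc(C)ccc1S(=O)(=O)NC1=NCCN1C(=S)SN1CCn2c1nsc2=S`: >= 20000 nM
compound 3, `COc1ccc(S(=O)(=O)NC2=NCCN2C(=S)SN2CCn3c2nsc3=S)cc1`: >= 20000 nM

The value of compound 1 in this assay is a limit of the assay, not a number. The value of compound 2 is likewise a limit. The value of compound 3 is also a limit. Compound 1 therefore stands at the top of the shown values, where every shown value rests, as the limit of >= 20000 nM in this assay, at which 3 of the 3 values shown sit, records.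

The unmeasured compound 4, `CC(=O)Nc1ccc(S(=O)(=O)NC2=NCCN2C(=S)SN2CCn3c2nsc3=S)cc1`, differs from compound 1 by acetamido in place of hydrogen on an aromatic carbon. The steps that come nearest are a step that the two limits leave unreadable from compound 1 to compound 3, a change at the same kind of aromatic carbon of the shared core, and a step that the two limits leave unreadable from compound 1 to compound 2, together with a step that the two limits leave unreadable from compound 2 to compound 3; all three remain unreadable, since both ends sit at the limit. No step among the shown compounds has moved any value away from that limit, so nothing here points to a gain in this assay from acetamido in place of hydrogen on an aromatic carbon.

Compound 4 is therefore expected to behave like compound 1, with a step of a number no higher from compound 1 to compound 4 (the limit leaves the size open) that is most likely to leave it at the limit. The estimate for compound 4 in this assay is 20000 nM, within a range from 6000 nM to 60000 nM.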

Compound 4, concentration for 50% growth inhibition: >= 20000 nM
Compound 4 ended at the assay's limit; the forecaster's own chance of this, stated with the estimate: 80%; the middle value lies on the limit itself.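

The steps from compound 1, compound 2 and compound 3 to compound 4 cannot be read in this assay, and each of the four values is a limit, not a number: the limit of >= 20000 nM in this assay, at which 4 of the 4 values shown sit.

The compounds shown leave open how far apart these four compounds truly lie, and whether any change to the shared core would bring a value off this limit.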